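A few compounds are considered here, and "the series" means these few. Any claim that something is new, unique, unknown or untested is made for them only; others in the source may bear on it.

The series shares the core of compound 1 `Cc1cccc(-c2noc(COc3ccc(CCC(=O)O)cc3Cl)n2)c1`, which in a functional assay on CHO cells for agonist activity at Free fatty acid receptor 1 (Homo sapiens), read by FLIPR and calcium flux, in the presence of a further agent that is not named here (on this read-out higher numbers stand for an effect only at larger amounts of compound and lower numbers for an effect already at smaller amounts), gives 4580 nM. Compound 2 `Cc1cc(-c2noc(COc3ccc(CCC(=O)O)cc3)n2)ccc1F` gives 2120 nM in this assay, and compound 3 `CC(Oc1ccc(CCC(=O)O)cc1)c1nc(-c2cccs2)no1` gives 4000 nM. Of these three numbers compound 1 carries the highest; the value of compound 3 sits within the usual scatter of it, whereas the value of compound 2 lies beyond the scatter and is the lower one. No pair of these compounds differs in one place only, so no single step between measured compounds can be read from them.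

Compound 4 `O=C(O)CCc1ccc(OCc2nc(-c3ccccc3)no2)c(Cl)c1` is not yet measured. It differs from compound 1 by hydrogen in place of methyl on an aromatic carbon, meta to a large group, which cut one bond further out reads 3-methylphenyl to phenyl. With no measured step of this kind in hand, the expected change in this assay is a 1.2-fold higher number from compound 1 to compound 4 (0.08 log units; within the scatter), no larger than the usual scatter and in no firm direction. For compound 4 in this assay the estimated value is 5500 nM, with a range from 2300 nM to 13000 nM.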

Compound 4, half-maximal effective concentration: 13100 nM
The estimate for compound 4 lay 2.4-fold (0.38 log units) below the measured number, outside the stated range (above it).
By their numbers in this assay, from the lowest: compounds 2, 3 and 1 (each within the scatter of the next, the first and the last beyond it); then compound 4.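

The methyl of the 3-methylphenyl group is not a silent feature in this assay: replacing it with hydrogen to leave phenyl gives a 2.9-fold higher number from compound 1 to compound 4 (0.46 log units; beyond the scatter), the only single-place change shown so far. This position, meta to a large group, therefore responds even to a change as small as the loss of one methyl, and within this pair the methyl goes with the lower number. Nothing measured here gives a reason for this step.

Going by these compounds, whether an ethyl, a methoxy group or a fluorine at this position would match the methyl, improve on it or fall back towards hydrogen remains open. So does whether the step keeps its size and direction elsewhere in the series, since it rests on one pair of compounds.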